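Shortening the side chain: compound 1 to compound 4

The compounds below may be only part of what the source reports. "The series", "measured", "known", "first", "only" and "open" are said of these compounds alone.

compound 1 `COc1cc(OCc2cccc(COc3ccccc3)c2)c2cc(-c3cn4nc(OC)sc4n3)oc2c1` 3.2 nM
compound 2 `COc1cc(OCc2ccccc2OCc2ccccc2)c2cc(-c3cn4nc(OC)sc4n3)oc2c1` 3.2 nM
compound 3 `COc1nn2cc(-c3cc4c(OC)cccc4o3)nc2s1` 7.6 nM

In a functional assay on HEK293 cells for antagonist activity at proteinase-activated receptor 4 (Homo sapiens), read by FLIPR and calcium flux, with a stated time of 30 min (on this read-out lower numbers stand for stronger inhibition and higher numbers for weaker inhibition), compound 1 gives 3.2 nM, level at the digits shown with compound 2 and together with it the lowest of the three numbers. Compound 3, which carries the shared core without the extended side chain, gives 7.6 nM, a number beyond the scatter above compound 1. Compounds 1 and 2 show that moving the outer group around the inner ring leaves the read-out unchanged within the scatter, while compound 3 shows that removing the whole side chain costs some potency.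

Compound 4 `COc1cc(OCc2cccc(Oc3ccccc3)c2)c2cc(-c3cn4nc(OC)sc4n3)oc2c1` is the next structure in this line. Against compound 1 the change is phenoxy in place of phenoxymethyl on an aromatic carbon: the side chain keeps its outer ring but loses one carbon of the link. Among the measured compounds shown here, no pair of measured compounds isolates exactly this change. The closest guidance is the indifference of the read-out to the placement of the outer group between compounds 1 and 2, and the moderate loss on removing the side chain altogether in compound 3.

For this assay compound 4 is therefore expected to stay near compound 1, with at most a small loss. The step of a 1.6-fold higher number from compound 1 to compound 4 (0.19 log units; within the scatter) is the expected size, inside or at the edge of the scatter. Compound 4 is estimated at 5 nM, within a range of 2 nM to 15 nM.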

Compound 4, half-maximal inhibitory concentration: 1.2 nM
For compound 4 the middle estimate is 4.2-fold (0.62 log units) above the measured one; the whole stated range lies above it.
By their numbers in this assay, from the lowest: compound 4; then compounds 1 and 2 (each within the scatter of the next); then compound 3.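

In this assay, phenoxy in place of phenoxymethyl on an aromatic carbon, meta to a large group, gives a 2.7-fold lower number from compound 1 to compound 4 (0.43 log units; beyond the scatter) as a modest step, but one that lies beyond the scatter. Among the compounds shown here, the earlier compounds gave no measured step in one place, so this is the first sign that the read-out at this position responds to the link itself, with the outer ring kept and the hydrogen-bond donor and acceptor counts unchanged between the two groups. No measurement on hand explains why the shorter link gives the lower number.

The compounds shown leave open whether the link can be trimmed further or swapped, for example for a phenyl group bonded directly to the inner ring, or for a thioether or an amine as the link, and whether a longer chain would reverse the step. They also leave open whether the same change carries over to the outer-group placement of compound 2, and whether a fluoro substituent or a pyridine ring in the outer position would keep the number this low.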